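Replacing a Methylindazole with a Pyridine-Fused Ring

The source may hold more compounds than are shown below. What is called first, only, known or untested is meant among the compounds shown, and "the series" means these compounds.

Compound 1 `O=C(Nc1ccc(-n2ncc3c(Cl)cccc32)cc1)Nc1ccc(Cl)c(C(F)(F)F)c1`, in a functional assay on LoVo cells (Homo sapiens) for cytotoxicity, read by MTT assay, with a stated time of 72 h; on this read-out lower numbers stand for stronger inhibition and higher numbers for weaker inhibition: 3600 nM
Compound 2 `Cc1cccc2c1cnn2-c1ccc(NC(=O)Nc2ccc(Cl)c(C(F)(F)F)c2)cc1`, in this assay: 3900 nM

For the measured compounds named here, only two compounds carry numbers, and they sit side by side: the single measured step, a 1.1-fold higher number from compound 1 to compound 2 (0.03 log units; within the scatter), lies within the scatter, so compound 2 cannot be told apart from compound 1 on this read-out. Compound 3 `O=C(Nc1ccc(-n2ncc3cccnc32)cc1)Nc1ccc(Cl)c(C(F)(F)F)c1` differs from compound 2 by a group of 9 heavy atoms (6 carbon, 3 nitrogen; one five-membered aromatic ring with 2 hetero atoms, one six-membered aromatic ring with 1 hetero atom) in place of a group of 10 heavy atoms (8 carbon, 2 nitrogen; one five-membered aromatic ring with 2 hetero atoms, one six-membered aromatic ring of carbon only), on an aromatic carbon. Going by the values given here, no measured step bears on this exchange. Among the compounds with values here, the one step available concerns a methyl in place of a chloro on a different part of the shared core and was itself within the scatter, so it gives no direction for a change of the whole ring system. With nothing pointing either way, the expected step of a 1.2-fold higher number from compound 2 to compound 3 (0.06 log units; within the scatter) is none beyond the scatter, with wide uncertainty. Compound 3 is therefore estimated at 4500 nM in this assay, within a range of 1500 nM to 14000 nM.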

Compound 3, half-maximal inhibitory concentration: 32000 nM
Beside the measured number, compound 3's estimate is 7.1-fold (0.85 log units) below it, outside the stated range (above it).
By their numbers in this assay, from the lowest: compounds 1 and 2 (each within the scatter of the next); then compound 3.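

For the compounds shown here, this is the first change in the piece that moves the number beyond the scatter: in this assay there is an 8.2-fold higher number from compound 2 to compound 3 (0.91 log units; beyond the scatter), and an 8.9-fold higher number from compound 1 to compound 3 (0.95 log units; beyond the scatter), whereas methyl and chloro on the shared core could not be told apart. So at this place, para to a large group, the attached ring system matters to this cell read-out, at least for these compounds. Nothing measured here accounts for the size of these steps.

Compound 3 differs from compound 1 and compound 2 in two ways at once, having a hetero atom in its six-membered ring and neither chloro nor methyl, and these compounds cannot separate the two. Going by these compounds, a methoxy or an amine on that ring also remains open, as does a chloro or methyl on the nitrogen-containing ring of compound 3.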